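Shortening the Tail of a Malate Dehydrogenase Inhibitor

The source may hold more compounds than are shown below. What is called first, only, known or untested is meant among the compounds shown, and "the series" means these compounds.

Measured so far in an assay on isolated protein for inhibition of malate dehydrogenase, mitochondrial (Homo sapiens), with a stated time of 30 min; a lower number here means a stronger inhibitor, a higher number a weaker inhibitor:
compound 1 `COCCOc1ccc(C(=O)OC)cc1NC(=O)COc1ccc(C(C)(C)CC(C)(C)C)cc1` gives 29000 nM
compound 2 `COC(=O)c1cccc(NC(=O)COc2ccc(C(C)(C)CC(C)(C)C)cc2)c1` gives 8920 nM

Among the measured compounds shown here, compound 2 stands at the lower of the two numbers, the stronger inhibitor of the pair; its only neighbour is compound 1, separated by the step of a 3.3-fold lower number from compound 1 to compound 2 (0.51 log units; beyond the scatter). Compound 3 `CCCCCc1ccc(OCC(=O)Nc2cccc(C(=O)OC)c2)cc1` differs from compound 2 in one place: pentyl in place of 1,1,3,3-tetramethylbutyl on an aromatic carbon. For the measured compounds named here, no measured step bears on this position. Going by the values given here, the single step seen so far concerns the removal of the 2-methoxyethoxy group from a different part of the molecule, and it says nothing about a change to the group para to the large group. With no guidance of that kind, a small step in either direction is expected, possibly within the scatter. Compound 3 is therefore estimated at 12000 nM, with a range from 4000 nM to 40000 nM in this assay. The step of a 1.3-fold higher number from compound 2 to compound 3 (0.13 log units; within the scatter) is the expected outcome.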

Compound 3, half-maximal inhibitory concentration: > 40000 nM
Compound 3 gave a limit, no number (the forecaster's own chance of this, stated with the estimate: 15%); middle value at least 3.3-fold (0.52 log units) away from the limit.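

Replacing 1,1,3,3-tetramethylbutyl with pentyl on this aromatic carbon, para to a large group, gives an at least 4.4-fold higher number from compound 2 to compound 3 (0.65 log units; beyond the scatter) in this assay. The reading for compound 3 is a limit of the assay and not a number: the limit of > 40000 nM in this assay, at which 1 of the 3 values shown sits. The earlier step spoke only of the 2-methoxyethoxy group elsewhere on the molecule, whereas this one shows that the group at this second place also matters, and that pentyl here gives a clearly weaker inhibitor than 1,1,3,3-tetramethylbutyl.

Going by these compounds, with only a limit for compound 3, the full size of the loss stays unknown. Also open, on these data alone, is whether the loss follows the number of carbons or the shape of the group, which an octyl chain or a tert-butyl group at this place could help to separate.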